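Anilino Swap on a Chloropyrimidine Core: Compound 4 Predicted

The source may report more compounds than this note shows. Statements on the series, on what has been measured and on what is new or still open speak of the compounds shown alone.

Measured compounds:
Compound 1 `Cc1ccccc1Nc1nc(Nc2ccccc2)ncc1Cl` — in a functional assay on MCF7 cells (Homo sapiens) for inhibition, read by CCK-8 assay, with a stated time of 48 h (on this read-out lower numbers stand for stronger inhibition of growth and higher numbers for weaker inhibition of growth), compound 1 reports only the limit > 100000 nM, not a number.
Compound 2 `Cc1ccccc1Nc1nc(Nc2ccc(N3CCNCC3)cn2)ncc1Cl` — in this assay compound 2 gives 3410 nM.
Compound 3 `COc1ccccc1CNc1nc(Nc2ccc(N3CCN(C)CC3)cn2)ncc1Cl` — in this assay compound 3 reports only the limit > 100000 nM, not a number.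

Compound 3 therefore stands at the weak end of what has been measured; it sits at the limit of > 100000 nM in this assay, at which 2 of the 3 values shown sit, a point it shares with compound 1, and no number is known for it. For the measured compounds named here, compound 2, the only compound with a number, shows that this shared core can reach measurable growth inhibition in this assay.

Compound 4 `Cc1cc(C)c(Nc2nc(Nc3ccc(N4CCN(C)CC4)cn3)ncc2Cl)c(C)c1` differs from compound 3 by 2,4,6-trimethylphenyl in place of 2-methoxybenzyl on a nitrogen on an aromatic ring. Compound 4 also keeps the methylpiperazine of compound 3, whereas compound 2 carries a piperazine with a free nitrogen. Going by the values given here, with no measured step bridging these structures, the expectation rests on compound 2 alone: compound 4, whose amine bears an aryl rather than a benzyl group as in compound 2, is expected to show an improvement from compound 3 of roughly an at least 16-fold lower number from compound 3 to compound 4 (1.22 log units; beyond the scatter), well beyond the scatter. Compound 4 is estimated at 6000 nM, likely between 1000 nM and 60000 nM.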

Compound 4, concentration for 50% growth inhibition: 9470 nM
Compound 4: middle estimate off by 1.6-fold (0.20 log units), on the low side, within the range that was stated.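

In this assay, replacing 2-methoxybenzyl with 2,4,6-trimethylphenyl on the nitrogen gives an at least 10-fold lower number from compound 3 to compound 4 (1.02 log units; beyond the scatter), the first step read at this position. It shows that the group on this nitrogen can, with the methylpiperazine unchanged, decide whether a compound gives a number or only a limit. Compound 3 still reports a limit and not a number, and the full size of the step therefore remains unknown: the limit of > 100000 nM in this assay, at which 2 of the 4 values shown sit.

The compounds shown cannot separate the loss of the methoxy group from the change of a benzyl to a phenyl group on the nitrogen, as both occur in this one step. From the compounds shown here alone, it also remains open how a carboxylic acid or an amine on the 2,4,6-trimethylphenyl ring, or a free piperazine nitrogen in place of the methylpiperazine, would read in this assay.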